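Swapping nitrophenyl for pyridyl on a spiro thiophene core

A few compounds are considered here, and "the series" means these few. Any claim that something is new, unique, unknown or untested is made for them only; others in the source may bear on it.

In an assay on membranes from brain for displacement of a labelled ligand from Sigma non-opioid intracellular receptor 1 (Cavia porcellus), read by scintillation counting, with a stated time of 120 min (on this read-out higher numbers stand for weaker inhibition and lower numbers for stronger inhibition), compound 2 `COC1Cc2cc(-c3ccc([N+](=O)[O-])cc3)sc2C2(CCN(Cc3ccccc3)CC2)O1` gives 16 nM, the second highest of the three numbers recorded. Compound 1 `c1ccc(CN2CCC3(CC2)OCCc2c3csc2-c2ccccc2)cc1` gives 4.5 nM in this assay, a lower number, and compound 3 `COC1Cc2cc(-c3ccc(-c4ccccc4)cc3)sc2C2(CCN(Cc3ccccc3)CC2)O1` gives 211 nM, the highest. Among the compounds with values here, the one single-point step among the measured compounds, a 13-fold higher number from compound 2 to compound 3 (1.12 log units; beyond the scatter), shows that replacing the nitro group on compound 2 by a phenyl ring raises the number by a large margin. Compound 4 `COC1Cc2cc(-c3cccnc3)sc2C2(CCN(Cc3ccccc3)CC2)O1` differs from compound 2 by pyridin-3-yl in place of 4-nitrophenyl on an aromatic carbon. Within the data shown here, no measured step covers this exchange directly; the only step available, from compound 2 to compound 3, concerns a different replacement and can serve at most as a rough guide that changes at this position can move the number substantially. He therefore expects a modest upward step, a 2.2-fold higher number from compound 2 to compound 4 (0.34 log units; beyond the scatter), in this assay. His estimate for compound 4 is 35 nM, with a range from 9 nM to 140 nM.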

Compound 4, inhibition constant: 2.5 nM
Beside the measured number, compound 4's estimate is 14-fold (1.15 log units) above it; the measured number lies below the stated range.
By their numbers in this assay, from the lowest: compounds 4 and 1 (each within the scatter of the next); then compound 2; then compound 3.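

In this assay, placing pyridin-3-yl in place of 4-nitrophenyl on the aromatic carbon next to the ring sulfur gives a 6.4-fold lower number from compound 2 to compound 4 (0.81 log units; beyond the scatter). The earlier step at this group, a 13-fold higher number from compound 2 to compound 3 (1.12 log units; beyond the scatter), ran upward only, so the number at this position is now seen to move in both directions from compound 2, and a single six-membered aromatic ring with one hetero atom is enough to bring it down. Nothing among the data given explains why the number falls.

On these data alone, what pyridin-2-yl, pyridin-4-yl or an unsubstituted phenyl would give at this position remains open, so the role of the ring nitrogen and its placement cannot be separated from the loss of the nitro group. As far as these compounds go, whether an amine on the pyridine ring would move the number further also remains open.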